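Moving the ring attachment point in compound 1

The source may hold more compounds than are shown below. What is called first, only, known or untested is meant among the compounds shown, and "the series" means these compounds.

Compound 1, with the structure `Cc1cc(C)c(CN2CCc3c(Cl)cc([C@@H](CO)[C@@H]4CCCO4)c(Cl)c3C2=O)c(=O)[nH]1`, carries a hydroxymethyl group and a five-membered oxygen-containing ring on the aromatic part of its core. In a physicochemical assay for lipophilicity, at pH 7.4 (on this read-out higher numbers stand for higher lipophilicity and lower numbers for lower lipophilicity), compound 1 gives 2.1. Two related compounds with a methoxy group in place of the hydroxymethyl are also on record: compound 2, `COC(c1cc(Cl)c2c(c1Cl)C(=O)N(Cc1c(C)cc(C)[nH]c1=O)CC2)C1CCN(C(C)=O)CC1`, gives 2.9; 2.9 (2 entries) in this assay, and compound 3, `COC(c1cc(Cl)c2c(c1Cl)C(=O)N(Cc1c(C)cc(C)[nH]c1=O)CC2)C1CCOC1`, gives 3; 3; 3; 3 (4 entries). Among these three, compound 1 stands lowest, and it is the only one with a single entry rather than repeated ones.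

Compound 4, `Cc1cc(C)c(CN2CCc3c(Cl)cc([C@H](CO)[C@H]4CCOC4)c(Cl)c3C2=O)c(=O)[nH]1`, has not yet been measured. It has exactly the same atoms as compound 1, joined differently: a group of 8 heavy atoms (6 carbon, 2 oxygen; one five-membered non-aromatic ring with 1 hetero atom) in place of a group of 8 heavy atoms (6 carbon, 2 oxygen; one five-membered non-aromatic ring with 1 hetero atom), on an aromatic carbon. The ring is thus attached through a different one of its carbons, while the hydrogen-bond donor and acceptor counts stay the same.

Within the data shown here, no measured pair in this set shows the effect of such a change. With atoms and polar groups unchanged, the step is expected to stay within the usual scatter, in either direction at most a small amount. The expected step is no change at the digits printed from compound 1 to compound 4 (within the scatter). Compound 4 is therefore estimated at 2.1, with a likely range from 1.7 to 2.5.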

Compound 4, distribution coefficient: 2
Compound 4: the middle estimate sits 0.10 log units above what was measured; the range from low to high includes it.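

Among these compounds, the pair gives the first direct look at this change, which swaps one group of 8 heavy atoms for another with the same atoms, its five-membered non-aromatic ring now attached through a different ring carbon. In this assay, this gives a number 0.10 log units lower from compound 1 to compound 4 (within the scatter), so on an aromatic carbon ortho to a chloro group, the two ways of joining the ring cannot be told apart on this read-out, at least for this one pair. Nothing measured here offers an explanation for this result.

The compounds shown leave open whether the same would hold with a different group on the ring or chain, for example an amine or a carboxylic acid in place of the hydroxymethyl group. They also leave open whether a six-membered ring with one oxygen, attached through different carbons in the same way, would give an equally small step, and a single pair cannot settle how general this is.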